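Swapping Methyl for Bromo on the Sulfonyl Ring

This account rests on a few compounds, and the source may have more. Where it says the series, first, only, none or still open, it means among the compounds named here.

Within the data shown here, compound 1 `COc1cc(Nc2nc3ccccc3nc2S(=O)(=O)c2ccc(C)cc2)cc(OC)c1` was measured in a functional assay on A549 cells (Homo sapiens) for cytotoxicity, read by MTT assay, with a stated time of 72 h (a higher number here means a weaker inhibitor, a lower number a stronger inhibitor), where compound 1 gives 8060 nM, the highest of the three numbers so far. Compound 2 `COc1cc(Nc2nc3ccccc3nc2S(=O)(=O)c2ccc(C)cc2)cc(OC)c1OC` gives 5610 nM, and the step of a 1.4-fold lower number from compound 1 to compound 2 (0.16 log units; within the scatter) stays within the scatter. Compound 3 `Cc1ccc(S(=O)(=O)c2nc3ccccc3nc2Nc2cccc(N)c2)cc1` gives 1950 nM, reached by the step of a 4.1-fold lower number from compound 1 to compound 3 (0.62 log units; beyond the scatter). Compound 4 `COc1cc(Nc2nc3ccccc3nc2S(=O)(=O)c2ccc(Br)cc2)cc(OC)c1` differs from compound 1 by bromo in place of methyl on an aromatic carbon. Among the measured compounds shown here, both measured steps alter the group on the nitrogen, not the (4-methylphenyl)sulfonyl group, so neither bears directly on this change; no measured pair here touches that ring. The expectation is therefore a step of a 1.0-fold lower number from compound 1 to compound 4 (0.00 log units; within the scatter) that stays within the scatter. Compound 4 is expected to give about 8000 nM, with a range from 3000 nM to 20000 nM.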

Compound 4, half-maximal inhibitory concentration: 15900 nM
The estimate for compound 4 lay 2.0-fold (0.30 log units) below the measured number, and the stated range covers the measured number.
By their numbers in this assay, from the lowest: compound 3; then compounds 2, 1 and 4 (each within the scatter of the next, the first and the last beyond it).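

Among these compounds, this is the first look at the sulfonyl ring rather than the group on the nitrogen: in this assay, bromo in place of methyl gives a 2.0-fold higher number from compound 1 to compound 4 (0.30 log units; within the scatter) at this spot, para to a large group. This single swap therefore cannot be told apart from the normal variation between repeated measurements. No measurement available here explains the result.

As far as these compounds go, it remains open whether another group at this spot, such as an amine or a carboxylic acid, would give a step beyond the scatter. Also open, from the compounds shown here alone, is whether bromo would give a similar number alongside the 3-aminophenyl group of compound 3.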